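Chloro to fluoro exchange: working notes on the series

A few compounds are considered here, and "the series" means these few. Any claim that something is new, unique, unknown or untested is made for them only; others in the source may bear on it.

Values so far in a functional assay on A549 cells (Homo sapiens) for inhibition, read by MTT assay, with a stated time of 72 h (on this read-out lower numbers stand for stronger inhibition and higher numbers for weaker inhibition), are as follows:
- compound 1 `Fc1ccc(-c2nnc(SCCCN3CCN(c4nc5ccccc5o4)CC3)o2)cc1` gives 75700 nM
- compound 2 `Clc1ccc(-c2nnc(SCCCN3CCN(c4nc5ccccc5s4)CC3)o2)cc1` gives 110000 nM

Compound 2 at 110000 nM is the higher of the two numbers, but compound 1 at 75700 nM lies within the usual scatter of it, so the pair sets no real order.

The next compound is compound 3 `Fc1ccc(-c2nnc(SCCCN3CCN(c4nc5ccccc5s4)CC3)o2)cc1` and it is not yet measured. Its difference from compound 2 is fluoro in place of chloro on an aromatic carbon in full: fluoro in place of chloro on an aromatic carbon, para to a large group.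

Going by the values given here, no measured pair isolates this exchange. The expectation therefore rests only on compound 2 at 110000 nM and compound 1 at 75700 nM as the nearby values. No step beyond the scatter is expected in this assay for this exchange. The estimated step of a 1.2-fold lower number from compound 2 to compound 3 (0.09 log units; within the scatter) is expected to stay inside that scatter. For compound 3 the estimated value is 90000 nM with an expected range from 40000 nM to 200000 nM in this read-out.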

Compound 3, half-maximal inhibitory concentration: 71700 nM
The estimate for compound 3 lay 1.3-fold (0.10 log units) above the measured number; the range from low to high includes it.
By their numbers in this assay, from the lowest: compounds 3, 1 and 2 (each within the scatter of the next).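

Fluoro in place of chloro on an aromatic carbon, para to a large group, now stands isolated for the first time: in this assay the 4-chlorophenyl to 4-fluorophenyl exchange gives a 1.5-fold lower number from compound 2 to compound 3 (0.19 log units; within the scatter), so this change at this position does not separate from the scatter. With the 4-fluorophenyl group held constant, 1,3-benzothiazol-2-yl in place of 1,3-benzoxazol-2-yl on an amine nitrogen in a ring gives a 1.1-fold lower number from compound 1 to compound 3 (0.02 log units; within the scatter), which likewise cannot be told from the scatter. Compound 1 and compound 2 differ in two places and isolated neither exchange, whereas compound 3 links them and shows that neither single change has a readable effect in this read-out. No supporting data bear on the reason for this result.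

As far as these compounds go, whether any group at this position can move the number beyond the scatter stays open, since only chloro and fluoro appear there, and a methoxy group, an amine or a carboxylic acid would extend that comparison. From the compounds shown here alone, the effect of a longer chain in the shared core is also open.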